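Extending the methyl of compound 1 with a ketone-alkyne chain

The source may hold more compounds than are shown below. What is called first, only, known or untested is meant among the compounds shown, and "the series" means these compounds.

Two compounds are measured in a functional assay on HT-29 cells (Homo sapiens) for antiproliferative activity, read by CellTiter-Glo, with a stated time of 72 h; a higher number here means a weaker inhibitor, a lower number a stronger inhibitor. Compound 1 `Cc1cc(C)c(S(=O)(=O)N2CCC(N3CCC(C)CC3)CC2)c(C)c1` gives 0.9 nM in this assay. Compound 2 `CCc1cc(Br)ccc1S(=O)(=O)N1CCC(N2CCC(C)CC2)CC1`, which carries a different substitution pattern on its aromatic ring, gives 0.5 nM in this assay. The gap between the two numbers lies within the usual scatter of such measurements, so compound 1 and compound 2 cannot be told apart on potency; both inhibit cell growth at very low concentrations.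

Compound 3 `C#CCCC(=O)CC1CCN(C2CCN(S(=O)(=O)c3c(C)cc(C)cc3C)CC2)CC1` is not yet measured. It differs from compound 1 by (but-3-yn-1-yl)carbonyl in place of hydrogen on a saturated chain carbon bound to a saturated ring carbon. In plain terms, the methyl on the saturated ring of compound 1 grows into a longer chain ending in a ketone and a terminal alkyne, while everything else stays the same.

Going by the values given here, no measured pair shows what such an extension does here. Since compound 1 already gives 0.9 nM, there is little room for a stronger number, and a modest weakening is the more likely outcome. The step from compound 1 to compound 3 in this assay is therefore expected to be a 3.3-fold higher number from compound 1 to compound 3 (0.52 log units; beyond the scatter). Compound 3 is estimated at 3 nM, with a plausible range from 0.6 nM to 15 nM.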

Compound 3, half-maximal inhibitory concentration: 2.1 nM
Estimate against measurement, compound 3: 1.4-fold (0.15 log units) above; the range from low to high includes it.
By their numbers in this assay, from the lowest: compounds 2 and 1 (each within the scatter of the next); then compound 3.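

At this position, on a saturated chain carbon bound to a saturated ring carbon, this assay shows that a long addition is tolerated: placing (but-3-yn-1-yl)carbonyl on that carbon gives a 2.3-fold higher number from compound 1 to compound 3 (0.37 log units; beyond the scatter) and so costs only a modest amount of potency. Even with a chain ending in a ketone and a terminal alkyne in place of the simple methyl, compound 3 still gives 2.1 nM in this assay, so cell growth remains inhibited at very low concentrations, and the earlier compounds, which carry only the small methyl here, could not show this. Nothing available explains why the number rises by this amount.

Because the ketone and the alkyne enter together in a single change, these compounds cannot show which part of the chain accounts for the step, or whether the length of the chain matters on its own. A shorter chain holding only the ketone, a chain ending in an amine or a carboxylic acid, and a longer chain would each test how much more this position can carry, and in what form.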